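The source may hold more compounds than are shown below. What is called first, only, known or untested is meant among the compounds shown, and "the series" means these compounds.

Measured compounds:
- compound 1 `C=C1C(=O)OC[C@H]1CCOC(=O)Nc1ccc(I)cc1`: in a functional assay on RAW264.7 cells (Mus musculus) for inhibition, with a stated time of 30 min (a lower number here means a stronger inhibitor, a higher number a weaker inhibitor), compound 1 gives 490 nM
- compound 2 `C=C1C(=O)OC[C@H]1CCOC(=O)Nc1ccc(OC)cc1`: compound 2 gives 710 nM
- compound 3 `C=C1C(=O)OC[C@@H]1CCOC(=O)Nc1ccc(OC)cc1`: compound 3 gives 1090 nM

Compound 2 stands second highest of the three numbers in this assay. Its nearest neighbour is compound 1, with a 1.4-fold higher number from compound 1 to compound 2 (0.16 log units; within the scatter); the step to compound 3 is a 1.5-fold higher number from compound 2 to compound 3 (0.19 log units; within the scatter). The second step rests only on the fact that (the fact that compounds 2 and 3 differ only in the configuration as drawn). Neither step leaves the scatter, so the three compounds cannot be ordered against each other.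

Compound 4 `C=C1C(=O)OC[C@H]1CCOC(=O)Nc1ccc(CC)cc1` is not yet measured. It differs from compound 2 by ethyl in place of methoxy on an aromatic carbon. Within the data shown here, the one measured step that touches the same aromatic carbon is the exchange of iodo for methoxy, a 1.4-fold higher number from compound 1 to compound 2 (0.16 log units; within the scatter), which stayed within the scatter; the configuration step, a 1.5-fold higher number from compound 2 to compound 3 (0.19 log units; within the scatter), does not concern the aromatic substituent and also stayed within the scatter. Among the measured compounds shown here, no step has yet moved the number beyond the scatter, and nothing in the data singles out ethyl as a group that should do so.

The expectation for compound 4 in this assay is therefore a step of about a 1.0-fold lower number from compound 2 to compound 4 (0.01 log units; within the scatter), that is, none beyond the scatter. Compound 4 is estimated at 700 nM, with a range from 350 nM to 1400 nM.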

Compound 4, half-maximal inhibitory concentration: 840 nM
Estimate against measurement, compound 4: 1.2-fold (0.08 log units) below; low and high end bracket the measured number.
By their numbers in this assay, from the lowest: compounds 1, 2, 4 and 3 (each within the scatter of the next, the first and the last beyond it).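

In this assay, the aromatic carbon para to a large group has now carried iodo, methoxy and ethyl, and neither new exchange leaves the scatter: a 1.2-fold higher number from compound 2 to compound 4 (0.07 log units; within the scatter), and a 1.7-fold higher number from compound 1 to compound 4 (0.23 log units; within the scatter). The exchange of methoxy for ethyl keeps the count of 2 heavy atoms but takes away the hydrogen-bond acceptor of the substituent, and the number stays within the scatter; for this pair, then, an acceptor in the substituent at this position is not needed to keep the number in this range. Nothing measured here speaks to the cause of this flat behaviour at the aromatic carbon, and no information on the properties of these groups is available for the series.

Still open, on these data alone, is whether any group at this position can move the number beyond the scatter, for instance an amine, a carboxylic acid or a longer chain such as hexyl. Among these compounds, also open is whether the drawn configuration matters with other substituents, as the one pair differing in configuration carries methoxy.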